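Two Methyl Groups Added to the Hydrazone Aryl Ring

A few compounds are considered here, and "the series" means these few. Any claim that something is new, unique, unknown or untested is made for them only; others in the source may bear on it.

In a functional assay on HT-29 cells (Homo sapiens) for cytotoxicity, read by MTT assay, with a stated time of 72 h (a lower number here means a stronger inhibitor, a higher number a weaker inhibitor), compound 2 `CN(C)CCn1cnnc1-c1cc(Oc2ccc(NC(=O)N/N=C/c3cccc(O)c3)cc2F)ccn1` gives 330 nM, the lowest of the two numbers measured. Compound 1 `CN(C)CCn1cnnc1-c1cc(Oc2ccc(NC(=O)N/N=C/c3c(O)ccc4ccccc34)cc2F)ccn1` gives 670 nM in this assay, and the step between them is a 2.0-fold lower number from compound 1 to compound 2 (0.31 log units; beyond the scatter). Compound 3 `Cc1cc(/C=N/NC(=O)Nc2ccc(Oc3ccnc(-c4nncn4CCN(C)C)c3)c(F)c2)cc(C)c1O` differs from compound 2 by 4-hydroxy-3,5-dimethylphenyl in place of 3-hydroxyphenyl on a carbon with a double bond to nitrogen. Within the data shown here, the only measured step sits at the same place and was modest, so a change of similar or smaller size is expected, with no clear direction. Compound 3 is expected to give 400 nM, in a range from 150 nM to 1100 nM. The expected step is a 1.2-fold higher number from compound 2 to compound 3 (0.08 log units; within the scatter).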

Compound 3, half-maximal inhibitory concentration: 1220 nM
Beside the measured number, compound 3's estimate is 3.1-fold (0.48 log units) below it, outside the stated range (above it).
By their numbers in this assay, from the lowest: compound 2; then compounds 1 and 3 (each within the scatter of the next).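

Swapping the group on the carbon with a double bond to nitrogen can move the number beyond the scatter in this assay: 4-hydroxy-3,5-dimethylphenyl in place of 3-hydroxyphenyl gives (a 3.7-fold higher number from compound 2 to compound 3 (0.57 log units; beyond the scatter)). Against 2-hydroxynaphthalen-1-yl, the same group gives (a 1.8-fold higher number from compound 1 to compound 3 (0.26 log units; within the scatter)), so those two groups cannot be separated here. No measurement here explains these results.

On these data alone, the hydroxyl position and the two methyl groups change together, so their separate contributions remain unknown. A 4-hydroxyphenyl group would help to separate them, while a 3-aminophenyl group would test replacing the hydroxyl with an amine.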